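The source may hold more compounds than are shown below. What is called first, only, known or untested is meant among the compounds shown, and "the series" means these compounds.

- compound 1 `O=C(/C=C/c1cccnc1)NCCCCCCCc1ccc(S(=O)(=O)Nc2ccccc2)cc1`: 37.6 nM
- compound 2 `O=C(/C=C/c1cccnc1)NCCCCCCc1cccc(S(=O)(=O)Nc2ccccc2)c1`: 0.63 nM
- compound 3 `O=C(/C=C/c1cccnc1)NCCCCCCCc1cccc(S(=O)(=O)Nc2ccccc2)c1`: 42.6 nM

In a functional assay on MCF7 cells (Homo sapiens) for inhibition, read by CCK-8 assay, with a stated time of 72 h (a lower number here means a stronger inhibitor, a higher number a weaker inhibitor), compound 2 gives 0.63 nM, the lowest of the three numbers, which makes it the most potent of the set. Compound 1 and compound 3 both lie far above it, well beyond the usual scatter, and within that scatter of each other.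

The next compound to be tested is compound 4 `Cc1ccccc1NS(=O)(=O)c1cccc(CCCCCCNC(=O)/C=C/c2cccnc2)c1`. It differs from compound 2 in one place: methyl in place of hydrogen on an aromatic carbon. A methyl replaces a hydrogen on an aromatic carbon, ortho to a large group, turning phenyl into 2-methylphenyl.

For the measured compounds named here, no measured compound here carries a methyl on that phenyl, so the data offer no direct guide to this change. The expectation is therefore cautious. With compound 2 at 0.63 nM, the number seems to have more room to rise than to fall, so a modest weakening is more likely than a gain. The expected change, a 2.4-fold higher number from compound 2 to compound 4 (0.38 log units; beyond the scatter), is small, perhaps only slightly beyond the scatter. For compound 4 the estimated value in this assay is 1.5 nM, with an expected range of 0.3 nM to 8 nM.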

Compound 4, half-maximal inhibitory concentration: 0.226 nM
Beside the measured number, compound 4's estimate is 6.6-fold (0.82 log units) above it, and the stated range ends above it.
By their numbers in this assay, from the lowest: compound 4; then compound 2; then compounds 1 and 3 (each within the scatter of the next).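

In this assay, turning phenyl into 2-methylphenyl gives a 2.8-fold lower number from compound 2 to compound 4 (0.45 log units; beyond the scatter), a modest step but one that lies beyond the usual scatter. For the compounds shown here, until this result, no compound carried any change on this ring, so this is the first sign that the ring can take a methyl on this aromatic carbon without a loss of potency, and that the number can still fall from an already very low starting point. Nothing at hand explains why one added methyl lowers the number in these cells, so the result stands as an observation without a known cause.

A single small group at a single place is all that is shown here, so it remains open whether an ethyl, a chlorine or a methoxy group at the same carbon would also lower the number, or whether a larger group would reverse the gain. Going by these compounds, it also remains open whether the same methyl would have a similar effect on compound 1 or compound 3, which have the weaker numbers in this set.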